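Methoxy for Fluoro on a Benzyl Arm at the Limit

A few compounds are considered here, and "the series" means these few. Any claim that something is new, unique, unknown or untested is made for them only; others in the source may bear on it.

Measured so far:
compound 1, `CCOC(=O)c1ccc(-c2nn(C)c3ccccc23)cc1`: > 10000 nM
compound 2, `CCOC(=O)c1ccc(-c2nn(Cc3ccc(F)cc3)c3ccccc23)cc1`: > 10000 nM

In a functional assay on cells (Platelet, Homo sapiens) for inhibition (on this read-out lower numbers stand for stronger inhibition and higher numbers for weaker inhibition), compound 1 gives > 10000 nM, which is a limit of the assay and not a number. Compound 2 gives > 10000 nM, again a limit. Between the two lies a step that the two limits leave unreadable from compound 1 to compound 2; both values sit at the limit of > 10000 nM in this assay, at which 2 of the 2 values shown sit, so compound 2 stands at the edge of what this assay can report, with no number of its own.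

Compound 3, `CCOC(=O)c1ccc(-c2nn(Cc3ccc(OC)cc3)c3ccccc23)cc1`, differs from compound 2 in one place: methoxy in place of fluoro on an aromatic carbon. Among the compounds with values here, only one measured step exists here, and it is unreadable, so no measured change offers a size or a direction for this one. Two compounds at the limit give no reason to expect compound 3 to leave it, and the expectation is no step beyond the scatter. Compound 3 is therefore estimated to give about 15000 nM, within a range from 4000 nM to 50000 nM. That estimate means an expected step that the limit leaves unreadable from compound 2 to compound 3, most likely reported once more only as a limit.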

Compound 3, half-maximal inhibitory concentration: > 10000 nM
Compound 3 ended at the assay's limit; the forecaster's own chance of this, stated with the estimate: 80%; the middle value lies beyond the limit too.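

In this assay compound 3 gives > 10000 nM and this is a limit, not a number. Within the data shown here, no step among compound 1, compound 2 and compound 3 can be read: the limit of > 10000 nM in this assay, at which 3 of the 3 values shown sit. As far as these compounds go, what stays open is how strongly, if at all, these compounds inhibit, and whether swapping 4-fluorobenzyl for 4-methoxybenzyl changes that.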